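Chloro to fluoro on the pendant phenyl: cytotoxicity outlook

The source may report more compounds than this note shows. Statements on the series, on what has been measured and on what is new or still open speak of the compounds shown alone.

Compound 1 `O=[N+]([O-])c1ccc(-c2csc(N3N=C(c4ccc(Cl)s4)CC3c3ccc(F)cc3)n2)cc1` and compound 2 `Fc1ccc(C2CC(c3ccc(Cl)s3)=NN2c2nc(-c3ccc(Cl)cc3)cs2)cc1` share one core and differ only by chloro in place of nitro on an aromatic carbon. In an ADME assay on NIH3T3 cells (Mus musculus) for cytotoxicity, read by XTT assay, with a stated time of 24 h (a higher number here means a weaker inhibitor, a lower number a stronger inhibitor), compound 1 gives > 500 ug/mL, which is a limit of the assay rather than a number. In this assay compound 2 likewise gives > 500 ug/mL, again a limit. The step that the two limits leave unreadable from compound 1 to compound 2 cannot be read because of the limit of > 500 ug/mL in this assay, at which 2 of the 2 values shown sit. Among the measured compounds shown here, compound 2 thus stands at the limit with no number of its own, and the one other value shown beside it is also a limit.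

Compound 3 `Fc1ccc(-c2csc(N3N=C(c4ccc(Cl)s4)CC3c3ccc(F)cc3)n2)cc1` differs from compound 2 by fluoro in place of chloro on an aromatic carbon; cut one bond further out, the change reads 4-chlorophenyl to 4-fluorophenyl. For the measured compounds named here, the only measured step, a step that the two limits leave unreadable from compound 1 to compound 2, is itself of unreadable size, so nothing measured points to any step beyond the scatter here. Compound 3 is therefore expected to sit near the same limit, at an estimated 500 ug/mL with a range from 250 ug/mL to 800 ug/mL. The step this estimate implies, a number no higher from compound 2 to compound 3 (the limit leaves the size open), is expected to be no more than the scatter.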

Compound 3, half-maximal inhibitory concentration: > 500 ug/mL
Compound 3 ended at the assay's limit (the forecaster's own chance of this, stated with the estimate: 85%); the middle value sits exactly at the limit.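

No step among compound 1, compound 2 and compound 3 can be read in this assay, because all three values are limits of the assay rather than numbers: the limit of > 500 ug/mL in this assay, at which 3 of the 3 values shown sit.

The compounds shown leave open whether exchanging nitro, chloro and fluoro on the aromatic carbon changes the cytotoxicity of the shared core at all, and how the three compounds would rank.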